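Swapping chlorine for fluorine on the sulfonyl-bearing ring

A few compounds are considered here, and "the series" means these few. Any claim that something is new, unique, unknown or untested is made for them only; others in the source may bear on it.

Measured so far:
- compound 1, `CN(Cc1ccc(C2=NCCN2)cc1)C(=O)COCCN(C)S(=O)(=O)c1c(Cl)cccc1Cl`: 8.5
- compound 2, `COc1cc(C)c(S(=O)(=O)N(C)CCOCC(=O)N2CCN(CCCN(C)C)CC2)c(C)c1`: 7.9
- compound 3, `Cc1c(Cl)ccc(S(=O)(=O)N(C)CC(=O)NCC(=O)N(C)Cc2ccc(C3=NCCN3)cc2)c1Cl`: 7.2

In a functional assay on Umbilical vein for antagonist activity at B1 bradykinin receptor (Homo sapiens), using Schild analysis, with a stated time of 30 min (a lower number here means a less potent compound, a higher number a more potent compound, by a factor of ten per unit of this negative logarithm), compound 1 gives the highest of the three numbers; compound 2 sits lower by a gap beyond the scatter, and compound 3 lower still. Compound 4, `CN(Cc1ccc(C2=NCCN2)cc1)C(=O)COCCN(C)S(=O)(=O)c1c(F)cccc1F`, has not been measured. It differs from compound 1 in one place: 2,6-difluorophenyl in place of 2,6-dichlorophenyl on a sulfonyl sulfur. Among the compounds with values here, no measured pair shows this same exchange, so the size of the step is a guess. A moderate loss is expected, the step from compound 1 to compound 4 estimated at a number 0.60 log units lower from compound 1 to compound 4 (beyond the scatter). Compound 4 is therefore expected to give about 7.9, within a range of 7.2 to 8.6.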

Compound 4, negative logarithm of the antagonist equilibrium constant: 7.6
For compound 4 the middle estimate is 0.30 log units above the measured one, and the stated range covers the measured number.
By their numbers in this assay, from the lowest: compound 3; then compounds 4 and 2 (each within the scatter of the next); then compound 1.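

With the heavy-atom count unchanged, putting 2,6-difluorophenyl in place of 2,6-dichlorophenyl on a sulfonyl sulfur gives in this assay a number 0.90 log units lower from compound 1 to compound 4 (beyond the scatter) for this single exchange. Within the data shown here, this is the first direct comparison, and it shows that the identity of the halogen on this ring matters to antagonist potency.

As far as these compounds go, whether a plain phenyl or 2,6-dimethylphenyl would keep the potency of compound 1 remains open. No data shown here account for the size of this step.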